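From Methanesulfonamido Phenyl to Phenylethenyl on the Shared Core

The compounds below may be only part of what the source reports. "The series", "measured", "known", "first", "only" and "open" are said of these compounds alone.

Of the compounds shown here, three sharing one core have been measured in a functional assay on H4 cells for agonist activity at growth hormone secretagogue receptor type 1 (Homo sapiens), read by FLIPR; on this read-out lower numbers stand for an effect already at smaller amounts and higher numbers for an effect only at larger amounts of compound. Compound 1 `CC(C)(N)C(=O)N[C@H](COCc1ccccc1)c1nnnn1Cc1ccc(NS(C)(=O)=O)cc1` gives 259 nM, compound 2 `CC(C)(N)C(=O)N[C@H](COCc1ccccc1)c1nnn(Cc2ccc(NS(C)(=O)=O)cc2)n1` gives 986 nM, and compound 3 `CC(C)(N)C(=O)N[C@H](COCc1ccccc1)c1nnn(Cc2cccc(NS(C)(=O)=O)c2)n1` gives 868 nM. Compound 3 thus stands at the second highest of the three numbers; compound 2 is nearest to it, while compound 1 shows a lower number that lies beyond the scatter. Within the data shown here, the only single-point step among the measured compounds is a 1.1-fold lower number from compound 2 to compound 3 (0.06 log units; within the scatter), a change in where the methanesulfonamido group sits on the phenyl ring.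

Compound 4 `CC(C)(N)C(=O)N[C@H](COCc1ccccc1)c1nnn(C/C=C/c2ccccc2)n1` differs from compound 3 in another way: 2-phenylethenyl in place of 3-(methanesulfonamido)phenyl on a saturated chain carbon bound to an aromatic nitrogen. Among the measured compounds shown here, no measured step removes the methanesulfonamido group or replaces the phenyl ring by a phenylethenyl chain, so the recorded step from compound 2 to compound 3 bears only loosely on it, showing that moving the group on the ring changed little. The expected step in this assay is therefore uncertain and estimated as a modest rise, a 1.7-fold higher number from compound 3 to compound 4 (0.24 log units; within the scatter). Compound 4 is expected to give 1500 nM, within a range from 400 nM to 6000 nM.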

Compound 4, half-maximal effective concentration: 517 nM
Estimate against measurement, compound 4: 2.9-fold (0.46 log units) above; low and high end bracket the measured number.
By their numbers in this assay, from the lowest: compounds 1, 4, 3 and 2 (each within the scatter of the next, the first and the last beyond it).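

In this assay, among these compounds, the earlier compounds showed only that moving the methanesulfonamido group around the phenyl ring changed little. The exchange of that whole substituent for 2-phenylethenyl, on a saturated chain carbon bound to an aromatic nitrogen, gives a 1.7-fold lower number from compound 3 to compound 4 (0.23 log units; within the scatter) and a 1.9-fold lower number from compound 2 to compound 4 (0.28 log units; within the scatter), so compounds without the methanesulfonamido group, and without any hydrogen-bond donor or acceptor in this substituent, can still read in the same range. No supporting data on hand account for this result.

The compounds shown leave open how a saturated chain such as 3-phenylpropyl, or a carboxylic acid or an amine on the phenyl ring, would read at this place. They also leave open how 2-phenylethenyl would read on the core of compound 1.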